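Trisubstituted-core amide series: notes on the benzylamide step

A few compounds are considered here, and "the series" means these few. Any claim that something is new, unique, unknown or untested is made for them only; others in the source may bear on it.

Among the measured compounds shown here, compound 2 `COc1cc(-c2nnc(SCC(=O)Nc3ccccc3)n2N)cc(OC)c1OC` gives 8280 nM in a functional assay on HeLa cells (Homo sapiens) for antiproliferative activity, read by MTT assay, with a stated time of 48 h (a lower number here means a stronger inhibitor, a higher number a weaker inhibitor), the highest of the two numbers so far; compound 1 `COc1cc(-c2nnc(SCC(=O)c3ccc(C(F)(F)F)cc3)n2N)cc(OC)c1OC` gives 3380 nM, and the step of a 2.4-fold higher number from compound 1 to compound 2 (0.39 log units; beyond the scatter) is the only measured one. Compound 3 `COc1cc(-c2nnc(SCC(=O)NCc3ccc(C)cc3)n2N)cc(OC)c1OC` carries 4-methylbenzyl in place of phenyl on an amide-type nitrogen. For the measured compounds named here, no measured step touches the amide nitrogen; the step from compound 1 to compound 2 changed the carbonyl substituent instead and does not bear on this change. For compound 3 the expected step is therefore small, a 1.4-fold lower number from compound 2 to compound 3 (0.14 log units; within the scatter), with direction uncertain. Compound 3 is estimated at 6000 nM, within 2000 nM to 18000 nM.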

Compound 3, half-maximal inhibitory concentration: > 100000 nM
Compound 3 gave a limit, no number; the forecaster's own chance of this, stated with the estimate: 10%; middle value at least 16-fold (1.22 log units) away from the limit.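

The amide-type nitrogen, untouched by the earlier step, does not accept every group: 4-methylbenzyl in place of phenyl there gives an at least 12-fold higher number from compound 2 to compound 3 (1.08 log units; beyond the scatter) in this assay. On the carbonyl carbon, (4-methylbenzyl)amino in place of 4-(trifluoromethyl)phenyl gives an at least 29-fold higher number from compound 1 to compound 3 (1.47 log units; beyond the scatter). Compound 3 gives a limit and not a number: the limit of > 100000 nM in this assay, at which 1 of the 3 values shown sits.

Which part of the change carries the loss stays open, whether the added methyl or the added carbon between ring and nitrogen. An unsubstituted benzyl or a 4-methylphenyl on this nitrogen would separate the two.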